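The compounds below may be only part of what the source reports. "The series", "measured", "known", "first", "only" and "open" are said of these compounds alone.

Compound 1, `O=C1N(Cc2ccc(Cl)cc2Cl)c2cccn2S(=O)(=O)N1Cc1ccccc1`, is one of the two compounds measured here. In an ADME assay on MT4 cells (Homo sapiens) for cytotoxicity, read by MTT assay, with a stated time of 5 days (a lower number here means that less compound is tolerated, a higher number that more compound is tolerated), compound 1 gives 218000 nM. Compound 2, `O=C1N(Cc2ccccc2Cl)c2cccn2S(=O)(=O)N1Cc1cccc(Br)c1`, differs from compound 1 in both benzyl groups. For compound 2 this assay reports only a limit, > 260000 nM, not a number. That limit is the one marked by the limit of > 260000 nM in this assay, at which 1 of the 2 values shown sits. Where compound 2 stands on the numbers shown is thus open at the top, and nothing in the two results orders compound 2 against compound 1.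

Compound 3, `O=C1N(Cc2ccc(Cl)cc2Cl)c2cccn2S(=O)(=O)N1Cc1cccc(Br)c1`, is not yet measured in this assay. It differs from compound 2 by chloro in place of hydrogen on an aromatic carbon. For the measured compounds named here, no step between two measured compounds carries this change alone, so no size can be read from the numbers. Both results gathered so far sit close to one another, which gives no reason to expect a step beyond the scatter in either direction. Compound 3 is expected to give 230000 nM, with a range from 140000 nM to 300000 nM. The step from compound 2 to compound 3 that this estimate means is an at least 1.1-fold lower number from compound 2 to compound 3 (0.05 log units; that floor lies within the scatter), expected to stay within the scatter.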

Compound 3, half-maximal cytotoxic concentration: > 243000 nM
Compound 3: a limit, no number (the forecaster's own chance of this, stated with the estimate: 40%); at least 1.0-fold (0.02 log units) between middle value and limit.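

In this assay compound 3 gives > 243000 nM, which is a limit and not a number. For the compounds shown here, the one step that can be read comes with the entry of a bromo group: it is an at least 1.1-fold higher number from compound 1 to compound 3 (0.04 log units; that floor lies within the scatter), so the two compounds that differ by this bromo group now have a floor for their step, though that floor shows no change that can be told from the scatter. Compound 2 and compound 3 both carry only limits, so the step from 2-chlorobenzyl to 2,4-dichlorobenzyl, with chloro entering para to a large group, cannot be read, and this position gives no size for the chloro group.

The compounds shown leave open how far the true values of compound 2 and compound 3 lie past their limits, and so whether chloro at this position changes the number at all. They also leave open what a group of another kind, such as an amine or a carboxylic acid, would give on either benzyl group in place of the chloro or bromo.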